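The source may hold more compounds than are shown below. What is called first, only, known or untested is meant among the compounds shown, and "the series" means these compounds.

Measured in a functional assay on A549 cells (Homo sapiens) for antiproliferative activity, read by MTT assay, with a stated time of 48 h; a lower number here means a stronger inhibitor, a higher number a weaker inhibitor:
compound 1 `N#CC1=C(N)Oc2c(c3nc4ccccc4nc3c3ccccc23)C12C(=O)N(Cc1cnnn1-c1ccc(Br)cc1)c1ccccc12`: 44300 nM
compound 2 `COc1ccc(-n2nncc2CN2C(=O)C3(C(C#N)=C(N)Oc4c3c3nc5ccccc5nc3c3ccccc43)c3ccccc32)cc1`: only a limit of the assay, > 50000 nM
compound 3 `CCOc1ccccc1-n1nncc1CN1C(=O)C2(C(C#N)=C(N)Oc3c2c2nc4ccccc4nc2c2ccccc32)c2ccccc21`: only a limit of the assay, > 50000 nM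

Compound 3 therefore stands not at a number but at the assay ceiling, (the limit of > 50000 nM in this assay, at which 2 of the 3 values shown sit). The step to compound 4 `Cc1cc(C)cc(-n2nncc2CN2C(=O)C3(C(C#N)=C(N)Oc4c3c3nc5ccccc5nc3c3ccccc43)c3ccccc32)c1` changes the group on the triazole nitrogen: 3,5-dimethylphenyl in place of 2-ethoxyphenyl on an aromatic nitrogen. Going by the values given here, two measured steps touch the same position. Among the compounds with values here, the one from compound 1 to compound 3 is an at least 1.1-fold higher number from compound 1 to compound 3 (0.05 log units; that floor lies within the scatter), a floor that says little, and the one between the two limits is a step that the two limits leave unreadable from compound 2 to compound 3. No direction beyond the scatter can thus be read for this assay. Compound 4 is expected to stay near the ceiling, an estimated step that the limit leaves unreadable from compound 3 to compound 4, giving an estimate of 60000 nM within 25000 nM to 150000 nM.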

Compound 4, half-maximal inhibitory concentration: > 50000 nM
Compound 4: only a limit was reported; the forecaster's own chance of this, stated with the estimate: 65%; the middle value is on the limit's open side.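

Compound 4 carries 3,5-dimethylphenyl, with no oxygen in the group on this aromatic nitrogen, yet in this assay it also gives only a limit of the assay, as the alkoxy-bearing compound 2 and compound 3 do. Going by these compounds alone, the steps among compound 2, compound 3 and compound 4 cannot be read, and the only readable new step is an at least 1.1-fold higher number from compound 1 to compound 4 (0.05 log units; that floor lies within the scatter). A third compound now rests at the ceiling: the limit of > 50000 nM in this assay, at which 3 of the 4 values shown sit.

Going by these compounds, whether a phenyl group carrying an amine or a carboxylic acid at this position would give a measurable number stays open.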